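Amide versus amino-alcohol side chains on the piperidine nitrogen

The source may report more compounds than this note shows. Statements on the series, on what has been measured and on what is new or still open speak of the compounds shown alone.

Compound 2 `COc1cc(N)c(Cl)cc1C(=O)NC1CCN(CC2CCN(CC(O)CN)CC2)CC1` stands highest of the two numbers in an assay on striatum for inhibition of 5-hydroxytryptamine receptor 4 (Cavia porcellus), read by radioligand binding; a higher number here means a weaker inhibitor, a lower number a stronger inhibitor; compound 2 gives 14.4 nM, and compound 1 `COc1cc(N)c(Cl)cc1C(=O)NC1CCN(CC2CCN(C(=O)CN)CC2)CC1` gives 9.3 nM, a gap within the scatter, so no order is read into it. The step of a 1.5-fold higher number from compound 1 to compound 2 (0.19 log units; within the scatter) is the only measured one that touches this position. Compound 3 `COc1cc(N)c(Cl)cc1C(=O)NC1CCN(CC2CCN(C(=O)C(C)(C)N)CC2)CC1` carries (1-amino-1-methylethyl)carbonyl in place of 3-amino-2-hydroxypropyl on an amine nitrogen in a ring, returning to a carbonyl-linked amine as in compound 1. Given that exchanging such groups gave a 1.5-fold higher number from compound 1 to compound 2 (0.19 log units; within the scatter), no step beyond the scatter is expected for a 1.4-fold lower number from compound 2 to compound 3 (0.16 log units; within the scatter). Compound 3 is estimated at 10 nM, range 4 nM to 25 nM.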

Compound 3, half-maximal inhibitory concentration: 2.6 nM
Compound 3: the middle estimate sits 3.8-fold (0.59 log units) above what was measured; measured number outside the range, below it.
By their numbers in this assay, from the lowest: compound 3; then compounds 1 and 2 (each within the scatter of the next).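

In this assay the carbonyl-linked side chain now shows a step beyond the scatter, which the earlier pair did not: 1-amino-1-methylethyl in place of aminomethyl on the carbonyl carbon gives a 3.6-fold lower number from compound 1 to compound 3 (0.55 log units; beyond the scatter) at this position. Exchanging 3-amino-2-hydroxypropyl for (1-amino-1-methylethyl)carbonyl gives a 5.5-fold lower number from compound 2 to compound 3 (0.74 log units; beyond the scatter) and so places compound 3 lowest of the three.

Open, going by these compounds, is whether a single methyl group or an ethyl group on that carbon gives a step of like size. Nothing at hand bears on the reason for either step.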